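This account rests on a few compounds, and the source may have more. Where it says the series, first, only, none or still open, it means among the compounds named here.

Measured so far in an ADME assay on Vero 76 cells (Chlorocebus sabaeus) for cytotoxicity, read by MTT assay, with a stated time of 96 h; on this read-out higher numbers stand for lower toxicity in this test and lower numbers for higher toxicity in this test:

compound 1 `Cc1ccccc1C1CC(c2ccc(OCc3ccccc3)cc2)=NN1c1ccc(S(N)(=O)=O)cc1` gives 100000 nM
compound 2 `NS(=O)(=O)c1ccc(N2N=C(c3ccc(OCc4ccccc4)cc3)CC2c2ccc(F)cc2)cc1` gives 90000 nM
compound 3 `Cc1cccc(C2CC(c3ccc(Oc4ccccc4)cc3)=NN2c2ccc(S(N)(=O)=O)cc2)c1` gives 81000 nM

Compound 2, at 90000 nM, lies within the usual scatter of both compound 1 and compound 3, so these numbers cannot be ranked against one another.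

The next compound to test is compound 4 `Cc1ccc(C2CC(c3ccc(OCc4ccccc4)cc3)=NN2c2ccc(S(N)(=O)=O)cc2)cc1`, which differs from compound 2 in one place: methyl in place of fluoro on an aromatic carbon. This is methyl in place of fluoro on an aromatic carbon, para to a large group, so 4-fluorophenyl becomes 4-methylphenyl.

Within the data shown here, one measured step bears on this swap, since it also exchanges a methyl-bearing ring for the fluoro-bearing one. That step is a 1.1-fold lower number from compound 1 to compound 2 (0.05 log units; within the scatter), and it stays within the scatter. A single step is thin evidence, but it gives no reason to expect a real shift in this assay. The expected change is no change at the digits printed from compound 2 to compound 4 (within the scatter), which is no step beyond the scatter. For compound 4 the estimated value is 90000 nM, with an expected range of 60000 nM to 100000 nM.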

Compound 4, half-maximal cytotoxic concentration: 100000 nM
Estimate against measurement, compound 4: 1.1-fold (0.05 log units) below; low and high end bracket the measured number.
By their numbers in this assay, from the lowest: compounds 3, 2, 1 and 4 (each within the scatter of the next).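

In this assay, the new result tests the exchange of fluoro and methyl directly on this aromatic carbon, and it gives a 1.1-fold higher number from compound 2 to compound 4 (0.05 log units; within the scatter), so the two numbers cannot be told apart. The same holds for the place of the methyl on this ring: 4-methylphenyl in place of 2-methylphenyl gives no change at the digits printed from compound 1 to compound 4 (within the scatter). No measurement at hand offers an explanation for these results.

Every step shown stays within the scatter, so it remains open which change at this ring, if any, would shift the number in this test. On these data alone, an amine, a carboxylic acid or a longer chain on the same aromatic carbon could answer that, and how any of them would read here is unknown.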